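A few compounds are considered here, and "the series" means these few. Any claim that something is new, unique, unknown or untested is made for them only; others in the source may bear on it.

Measured compounds:
compound 1 `O=C1NC(=S)S/C1=C\c1ccc(-c2ccc(C(=O)O)c(O)c2)o1` — > 72000 nM
compound 2 `Cc1cc(-c2ccc(C(=O)O)c(O)c2)oc1/C=C1\SC(=S)NC1=O` — "not determined" (no result reported)

Compound 1 `O=C1NC(=S)S/C1=C\c1ccc(-c2ccc(C(=O)O)c(O)c2)o1` was tested in an ADME assay on MT4 cells (Homo sapiens) for cytotoxicity, read by MTT assay; on this read-out lower numbers stand for higher toxicity in this test and higher numbers for lower toxicity in this test; its result is a limit of the assay and not a number, > 72000 nM. For compound 2 `Cc1cc(-c2ccc(C(=O)O)c(O)c2)oc1/C=C1\SC(=S)NC1=O` this assay holds no number at all, "not determined" (no result reported). For the measured compounds named here, compound 2 therefore stands on no figure of its own; the only value shown is the limit (the limit of > 72000 nM in this assay, at which 1 of the 2 values shown sits), and compound 2 cannot be placed relative to it.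

Compound 3 `COc1cc(-c2ccc(C(=O)O)c(O)c2)oc1/C=C1\SC(=S)NC1=O` carries methoxy in place of methyl on an aromatic carbon. Going by the values given here, no step between two measured compounds exists here, so the size of the change from compound 2 to compound 3 in this assay cannot be read from the data; with the single value shown sitting at the limit (the limit of > 72000 nM in this assay, at which 1 of the 2 values shown sits), no movement beyond the scatter is expected, and another limit is the likeliest outcome. Compound 3 is estimated at 80000 nM, within the range 30000 nM to 300000 nM.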

Compound 3, half-maximal cytotoxic concentration: > 125000 nM
Compound 3 gave a limit, no number; the forecaster's own chance of this, stated with the estimate: 70%; middle value at least 1.5-fold (0.19 log units) away from the limit.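

In this assay compound 1 gives a limit and no number, > 72000 nM. For the compounds shown here, compound 3 likewise gives a limit, > 125000 nM, so no step between compound 1 and compound 3 can be read. The compounds shown leave open at what concentration either becomes cytotoxic, and where compound 2 stands.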